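From 2-methoxyphenyl to 3-bromophenyl on a shared core

A few compounds are considered here, and "the series" means these few. Any claim that something is new, unique, unknown or untested is made for them only; others in the source may bear on it.

In a functional assay on PANC-1 cells (Homo sapiens) for inhibition, read by MTT assay, with a stated time of 24 h (a lower number here means a stronger inhibitor, a higher number a weaker inhibitor), compound 1 (`CC1(C)[C@H]2CC[C@]1(C)N(Cc1cn(-c3cccc(F)c3)nn1)C(=O)C2`), bearing 3-fluorophenyl, gives 220 nM as its reading. On the same scale, compound 2 (`CC1(C)[C@H]2CC[C@]1(C)N(Cc1cn(-c3ccc(C#N)cc3)nn1)C(=O)C2`), bearing 4-cyanophenyl, gives 250 nM and compound 3 (`COc1ccccc1-n1cc(CN2C(=O)C[C@@H]3CC[C@@]2(C)C3(C)C)nn1`), bearing 2-methoxyphenyl, gives 120 nM with the same core. Compound 3 stands apart from compound 2 alone: a 2.1-fold lower number from compound 2 to compound 3 (0.32 log units; beyond the scatter) is a modest gap, while a 1.8-fold lower number from compound 1 to compound 3 (0.26 log units; within the scatter) is no real separation.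

Compound 4 (`CC1(C)[C@H]2CC[C@]1(C)N(Cc1cn(-c3cccc(Br)c3)nn1)C(=O)C2`) carries 3-bromophenyl in place of 2-methoxyphenyl on an aromatic nitrogen is the whole change. All three measured steps swap the group at this same place, and they are small: besides the two above, a 1.1-fold higher number from compound 1 to compound 2 (0.06 log units; within the scatter) also stays within the scatter. The closest measured group by name is the 3-fluorophenyl of compound 1, so the expectation leans toward compound 1 and its 220 nM reading. The expected step, a 1.7-fold higher number from compound 3 to compound 4 (0.22 log units; within the scatter), is therefore small and upward. For compound 4 the estimate is 200 nM (expected range 100 nM to 400 nM).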

Compound 4, half-maximal inhibitory concentration: 90 nM
For compound 4 the middle estimate is 2.2-fold (0.35 log units) above the measured one; measured number below the stated range.
By their numbers in this assay, from the lowest: compounds 4, 3, 1 and 2 (each within the scatter of the next, the first and the last beyond it).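

In this assay, the bromo for fluoro swap on an aromatic carbon gives a 2.4-fold lower number from compound 1 to compound 4 (0.39 log units; beyond the scatter), so compound 1 now has a step beyond the scatter, which neither of its earlier steps reached. Against the two other groups the picture splits: a 2.8-fold lower number from compound 2 to compound 4 (0.44 log units; beyond the scatter) widens the separation from 4-cyanophenyl, while a 1.3-fold lower number from compound 3 to compound 4 (0.12 log units; within the scatter) leaves 3-bromophenyl and 2-methoxyphenyl unresolved, even though the group that leaves carries a hydrogen-bond acceptor and the one that enters carries none. Nothing shown accounts for these differences.

The compounds shown leave open whether a chloro or iodo group on the same aromatic carbon would read with the bromo or the fluoro compound. They also leave open how an amine or a carboxylic acid on the phenyl ring would read.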